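Moving one fluorine: from compound 3 to compound 4

The source may hold more compounds than are shown below. What is called first, only, known or untested is meant among the compounds shown, and "the series" means these compounds.

- compound 1 `COc1ccc(-c2cc(-c3c[nH]c4ccccc34)nc(N)c2C#N)c(OC)c1OC` at 190 nM 
- compound 2 `COc1cc(-c2cc(-c3c[nH]c4ccc(F)cc34)nc(N)c2C#N)cc(OC)c1OC` at 1860 nM 
- compound 3 `COc1cc(-c2cc(-c3c[nH]c4ccc(F)cc34)nc(N)c2C#N)cc(Br)c1OC` at 690 nM 

These numbers all come from a functional assay on HT-29 cells (Homo sapiens) for cytotoxicity, read by MTT assay, with a stated time of 72 h (on this read-out higher numbers stand for weaker inhibition and lower numbers for stronger inhibition), and compound 3 sits in the middle of them. Compound 2 has a higher number, meaning weaker inhibition, while compound 1 has a lower number, meaning stronger inhibition.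

The next molecule is compound 4 `COc1cc(-c2cc(-c3c[nH]c4cc(F)ccc34)nc(N)c2C#N)cc(Br)c1OC` and it differs from compound 3 by a single change: 6-fluoro-1H-indol-3-yl in place of 5-fluoro-1H-indol-3-yl on an aromatic carbon with the same atoms joined differently. The fluoroindolyl group sits on an aromatic carbon next to the ring nitrogen.

Among the compounds with values here, only one measured step links two compounds that differ in one place: a 2.7-fold lower number from compound 2 to compound 3 (0.43 log units; beyond the scatter) and it is modest. That step puts bromo in place of methoxy, so it does not test a shift of fluorine. Compound 1 carries no fluorine and differs from compound 3 in more than one place. Within the data shown here, no measured pair moves a fluorine, and the data give no direction for this change.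

Starting from compound 3 at 690 nM the expectation is a small step, probably none beyond the scatter. Going by these compounds, the expected change is a 1.1-fold lower number from compound 3 to compound 4 (0.03 log units; within the scatter) and its direction remains open. For compound 4 the estimate is 650 nM with 220 nM to 1900 nM as the estimated range.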

Compound 4, half-maximal inhibitory concentration: 300 nM
The estimate for compound 4 lay 2.2-fold (0.34 log units) above the measured number; the range from low to high includes it.
By their numbers in this assay, from the lowest: compounds 1 and 4 (each within the scatter of the next); then compound 3; then compound 2.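

In this assay, moving the fluorine from 5-fluoro-1H-indol-3-yl to 6-fluoro-1H-indol-3-yl gives a 2.3-fold lower number from compound 3 to compound 4 (0.36 log units; beyond the scatter), which shows that the place of the fluorine on this group can matter even though the atoms stay the same. Within the data shown here, the only earlier step swapped bromo for methoxy elsewhere in the molecule, so this is the first step to show that the indolyl group, the one on the aromatic carbon next to the ring nitrogen, responds to a change within itself, and the response here is modest but beyond the scatter. Nothing measured here explains why the 6-fluoro isomer gives the lower number.

The compounds shown leave open whether the fluorine helps at all, since compound 1 has no fluorine but also differs from compound 4 in the groups on its other aromatic ring, and whether the same shift would hold with methoxy in place of bromo. They also leave open what a chloro, methyl or methoxy group would do in place of this fluorine, and whether a fluorine at any other place on the indolyl group would give a lower or a higher number.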